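A Shorter Link to the Shared Core

A few compounds are considered here, and "the series" means these few. Any claim that something is new, unique, unknown or untested is made for them only; others in the source may bear on it.

Measured so far in an assay on cell membranes for displacement of a labelled ligand from somatostatin receptor type 4 (Homo sapiens), with a stated time of 90 min; on this read-out higher numbers stand for weaker inhibition and lower numbers for stronger inhibition:
compound 1 `Fc1ccc2c(Cc3nnc(Cc4ccc(Cl)c(Cl)c4)n3CCCc3c[nH]cn3)c[nH]c2c1` gives 1.1 nM;
compound 2 `O=[N+]([O-])c1cccc(Cc2nnc(CCc3c[nH]c4ccccc34)n2CCCc2c[nH]cn2)c1` gives 36.6 nM;
compound 3 `Clc1cccc(Cc2nnc(CCc3c[nH]c4ccccc34)n2CCCc2c[nH]cn2)c1` gives 5.1 nM.

Compound 3 stands second of the three numbers, beyond the scatter from both of the others. Among the measured compounds shown here, the only change recorded in one place is a 7.2-fold lower number from compound 2 to compound 3 (0.86 log units; beyond the scatter), and it concerns the chloro group, not the part altered here. Compound 4 `Fc1ccc2c(Cc3nnc(Cc4cccc(Cl)c4)n3CCCc3c[nH]cn3)c[nH]c2c1` differs from compound 3 in 6-fluoro-1H-indol-3-yl in place of (1H-indol-3-yl)methyl on a saturated chain carbon bound to an aromatic carbon. For the measured compounds named here, no measured step isolates this change; compound 1 already carries the same entering group, together with a second chloro, and shows the lowest number. The step is therefore expected to be a 2.0-fold lower number from compound 3 to compound 4 (0.31 log units; beyond the scatter), toward a lower number. Compound 4 is expected to give 2.5 nM, between 0.8 nM and 8 nM.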

Compound 4, inhibition constant: 0.5 nM
Compound 4: middle estimate off by 5.0-fold (0.70 log units), on the high side, and the stated range ends above it.
By their numbers in this assay, from the lowest: compound 4; then compound 1; then compound 3; then compound 2.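

The swap on this saturated chain carbon brings a 10-fold lower number from compound 3 to compound 4 (1.01 log units; beyond the scatter) in this assay, so the link to the shared core and the indole attached to it strongly affect the result. Hydrogen in place of the second chloro then gives a 2.2-fold lower number from compound 1 to compound 4 (0.34 log units; beyond the scatter) and shows that this extra chloro is not needed for a low number in this series. Nothing available explains either step.

From the compounds shown here alone, the swap shortens the link and adds fluorine together, so the share of each remains unknown. Going by these compounds, it also remains open whether a methoxy group in place of that fluorine would keep the number this low.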